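The source may hold more compounds than are shown below. What is called first, only, known or untested is meant among the compounds shown, and "the series" means these compounds.

The shared core of compound 1 `OC[C@H]1O[C@@H](n2cnc3c(SCCCc4ccccc4)ncnc32)[C@H](O)[C@@H]1O` carries a sulfur-linked substituent; in an assay on isolated protein for binding affinity to Equilibrative nucleoside transporter 1 (Homo sapiens) (a higher number here means a weaker inhibitor, a lower number a stronger inhibitor), compound 1 gives 1350 nM. Compound 2 `OC[C@H]1O[C@@H](n2cnc3c(Sc4ccccc4)ncnc32)[C@H](O)[C@@H]1O` gives 91200 nM in this assay, and compound 3 `Cc1cccc(CSc2ncnc3c2ncn3[C@@H]2O[C@H](CO)[C@@H](O)[C@H]2O)c1` gives 12000 nM. On these three numbers compound 3 stands second highest: its nearest neighbour is compound 2, with a 7.6-fold lower number from compound 2 to compound 3 (0.88 log units; beyond the scatter), and its furthest is compound 1, with an 8.9-fold higher number from compound 1 to compound 3 (0.95 log units; beyond the scatter). The widest gap in the set is a 68-fold higher number from compound 1 to compound 2 (1.83 log units; beyond the scatter).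

Compound 4 `Cc1ccc(CSc2ncnc3c2ncn3[C@@H]2O[C@H](CO)[C@@H](O)[C@H]2O)cc1` is not yet measured. It differs from compound 3 by 4-methylphenyl in place of 3-methylphenyl on a saturated chain carbon bound to a sulfur. Within the data shown here, no measured step moves the methyl group around the aromatic ring. The two steps that touch compound 3, a 7.6-fold lower number from compound 2 to compound 3 (0.88 log units; beyond the scatter) and an 8.9-fold higher number from compound 1 to compound 3 (0.95 log units; beyond the scatter), concern the size of what is tied to the sulfur, and both were modest. Neither bears on where the methyl sits. The expected step in this assay from this change is none beyond the scatter, read as no change at the digits printed from compound 3 to compound 4 (within the scatter). Compound 4 is estimated at 12000 nM, with a range of 4000 nM to 36000 nM.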

Compound 4, half-maximal inhibitory concentration: 457 nM
For compound 4 the middle estimate is 26-fold (1.42 log units) above the measured one; measured number outside the range, below it.
By their numbers in this assay, from the lowest: compound 4; then compound 1; then compound 3; then compound 2.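

In this assay, exchanging 3-methylphenyl for 4-methylphenyl on the saturated chain carbon bound to the sulfur, with the same atoms joined differently, gives a 26-fold lower number from compound 3 to compound 4 (1.42 log units; beyond the scatter), so placement of the methyl alone outweighs either modest step to compound 3 that changed what is tied to the sulfur. The 4-methylbenzyl group also compares well with phenyl on the sulfur, with a 200-fold lower number from compound 2 to compound 4 (2.30 log units; beyond the scatter), and with 3-phenylpropyl, with a 3.0-fold lower number from compound 1 to compound 4 (0.47 log units; beyond the scatter), making compound 4 the strongest inhibitor of the four. No measurement shown here accounts for this shift.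

Still open, as far as these compounds go, is whether 4-chlorobenzyl or 4-methoxybenzyl on the sulfur would follow 4-methylbenzyl. Unsubstituted benzyl is also absent from these compounds, so the size and direction of the effect of each methyl placement relative to it remain unknown.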